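The compounds below may be only part of what the source reports. "The series", "measured", "known", "first", "only" and "open" are said of these compounds alone.

Measured in a functional assay on MDA-MB-231 cells (Homo sapiens) for inhibition, read by CCK-8 assay, with a stated time of 48 h; on this read-out higher numbers stand for weaker inhibition of growth and lower numbers for stronger inhibition of growth:
- compound 1 `CN1CCN(c2ccc(Nc3ncc(Cl)c(NCc4ccc(C(F)(F)F)cc4)n3)nc2)CC1`: 19100 nM
- compound 2 `COc1ccc(CNc2nc(Nc3ccc(N4CCN(C)CC4)cn3)ncc2Cl)cc1`: 14900 nM

In this assay, going by the values given here, compound 2 lies within the scatter of compound 1, the only other measured compound, so the two cannot be ranked. Compound 3 `COc1ccccc1CNc1nc(Nc2ccc(N3CCN(C)CC3)cn2)ncc1Cl` has the same atoms as compound 2, joined differently: 2-methoxyphenyl in place of 4-methoxyphenyl on a saturated chain carbon bound to a nitrogen on an aromatic ring. It carries 2-methoxyphenyl in place of 4-methoxyphenyl on a saturated chain carbon bound to a nitrogen on an aromatic ring.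

Among the compounds with values here, no measured compound carries 2-methoxyphenyl, so the data offer no direct precedent. Within the data shown here, only one measured step bears on the change, and only indirectly: a 1.3-fold lower number from compound 1 to compound 2 (0.11 log units; within the scatter), with methoxy in place of trifluoromethyl on an aromatic carbon. That exchange of one group for a different one stayed within the scatter, so a shift of the methoxy group alone gives no ground to expect anything larger, and no direction can be favoured. The expected size is a 1.0-fold higher number from compound 2 to compound 3 (0.00 log units; within the scatter), which is no step beyond the scatter. For compound 3 the estimated value is 15000 nM, with an expected range of 7000 nM to 30000 nM.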

Compound 3, concentration for 50% growth inhibition: 29300 nM
The estimate for compound 3 lay 2.0-fold (0.29 log units) below the measured number, within the range that was stated.
By their numbers in this assay, from the lowest: compounds 2, 1 and 3 (each within the scatter of the next).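

In this assay, going by these compounds alone, exchanging 4-methoxyphenyl for 2-methoxyphenyl on a saturated chain carbon bound to a nitrogen on an aromatic ring gives a 2.0-fold higher number from compound 2 to compound 3 (0.29 log units; within the scatter), so this is the first sign that moving the methoxy group around its phenyl ring does not separate two compounds beyond the usual scatter. The exchange of 4-(trifluoromethyl)phenyl for 2-methoxyphenyl at the same place gives a 1.5-fold higher number from compound 1 to compound 3 (0.19 log units; within the scatter), which means that every pair among the three compounds now lies within the scatter and no group shown at this place can be ranked above another. Nothing available on these compounds offers an explanation for this result.

From the compounds shown here alone, whether an amine or a carboxylic acid on this phenyl ring, or a longer chain in place of the methoxy group, would take the number beyond the scatter stays open. Also open, going by these compounds, is whether changes to the shared core, which is the same in all three compounds, would shift growth inhibition more than any exchange at this place has done so far.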